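Amide aryl swap and mouse microsomal clearance

A few compounds are considered here, and "the series" means these few. Any claim that something is new, unique, unknown or untested is made for them only; others in the source may bear on it.

Measured so far:
compound 1 `CN1C[C@H](C(=O)Nc2ccc(F)cc2)[C@@H](c2ccc(/C=C/C(=O)Nc3ccccc3N)cc2)C1` — 34 mL/min/kg
compound 2 `CN1C[C@H](C(=O)Nc2ccc(Br)cc2)[C@@H](c2ccc(/C=C/C(=O)Nc3ccccc3N)cc2)C1` — 16 mL/min/kg
compound 3 `CN1C[C@H](C(=O)Nc2ccc(Cl)cc2F)[C@@H](c2ccc(/C=C/C(=O)Nc3ccccc3N)cc2)C1` — 43 mL/min/kg

In an in vitro ADME assay on microsomes from liver (Mus musculus) for pharmacokinetics, read by LC-MS, with a stated time of 10 min, tested at 1 uM (on this read-out lower numbers stand for slow clearance and higher numbers for fast clearance), compound 2 stands lowest of the three numbers, with compound 1 and compound 3 both beyond the scatter above it. Compound 4 `CN1C[C@H](C(=O)Nc2ccc(Cl)cn2)[C@@H](c2ccc(/C=C/C(=O)Nc3ccccc3N)cc2)C1` is the next step from compound 2: 5-chloropyridin-2-yl in place of 4-bromophenyl on an amide-type nitrogen. Going by the values given here, no measured pair swaps a carbon-only ring for a ring holding a nitrogen at this place, so the only bearing steps are a 2.1-fold lower number from compound 1 to compound 2 (0.33 log units; beyond the scatter) and a 2.7-fold higher number from compound 2 to compound 3 (0.43 log units; beyond the scatter), which show that every change at this amide nitrogen so far leaves compound 2 as the slow end. A modest rise is therefore expected, a 1.8-fold higher number from compound 2 to compound 4 (0.24 log units; within the scatter), with wide uncertainty. For compound 4 the estimate is 28 mL/min/kg, in the range 13 mL/min/kg to 60 mL/min/kg.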

Compound 4, clearance: 31 mL/min/kg
Beside the measured number, compound 4's estimate is 1.1-fold (0.04 log units) below it; low and high end bracket the measured number.
By their numbers in this assay, from the lowest: compounds 2, 4, 1 and 3 (each within the scatter of the next, the first and the last beyond it).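

The first ring holding a nitrogen at this amide-type nitrogen gives a number within the scatter of all three carbon-only rings in this assay (a 1.9-fold higher number from compound 2 to compound 4 (0.29 log units; within the scatter); a 1.4-fold lower number from compound 3 to compound 4 (0.14 log units; within the scatter); a 1.1-fold lower number from compound 1 to compound 4 (0.04 log units; within the scatter)). Compound 4 thus does not separate from either compound 2 or compound 3, although those two lie beyond the scatter of each other. No measurement shown gives a cause for these numbers.

From the compounds shown here alone, the ring nitrogen and the chlorine enter together, so their shares stay open. A 4-chlorophenyl or 5-bromopyridin-2-yl group at this place would separate them.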